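Replacing cyclobutyl with isopropyl on compound 3

This account rests on a few compounds, and the source may have more. Where it says the series, first, only, none or still open, it means among the compounds named here.

Values in a functional assay on PC-12 cells (Rattus norvegicus) for inhibition, read by sulforhodamine B assay (a higher number here means a weaker inhibitor, a lower number a stronger inhibitor), for the measured compounds
compound 1 `O=C1NC(=O)C(Cc2ccc(OCC3CCCC3)cc2)S1` gives 25000 nM in this series
compound 2 `O=C1NC(=O)C(Cc2ccc(OCC3CCC3)cc2)S1` gives > 100000 nM as a limit
compound 3 `O=C1NC(=O)/C(=C/c2ccc(OCC3CCC3)cc2)S1` gives 13000 nM in this series

In this assay compound 3 at 13000 nM and compound 1 at 25000 nM lie within the usual scatter of each other. The entry for compound 2 is a limit and not a number.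

Compound 4 `CC(C)COc1ccc(/C=C2\SC(=O)NC2=O)cc1` is the next entry to be read. It carries isopropyl in place of cyclobutyl on a saturated chain carbon bound to an oxygen on an aromatic ring, which also reads as cyclobutylmethoxy to isobutoxy.

Within the data shown here, one measured step bears on this place: an at least 4.0-fold higher number from compound 1 to compound 2 (0.60 log units; beyond the scatter) for cyclobutyl in place of cyclopentyl. That step is a single comparison, it ends at a limit, and it exchanges one ring for another, whereas the change here removes the ring. It therefore gives only weak guidance, and no step beyond the scatter is expected in this assay, with any drift more likely toward a higher number. The expected step is a 1.5-fold higher number from compound 3 to compound 4 (0.19 log units; within the scatter) on this reading. For compound 4 the estimated value is 20000 nM with an expected range from 7000 nM to 60000 nM for the coming measurement.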

Compound 4, half-maximal inhibitory concentration: 16000 nM
Estimate against measurement, compound 4: 1.3-fold (0.10 log units) above, and the stated range covers the measured number.
By their numbers in this assay, from the lowest: compounds 3, 4 and 1 (each within the scatter of the next). At a limit, above all of these: compound 2.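

In this assay, the step for opening the ring at this place is a 1.2-fold higher number from compound 3 to compound 4 (0.09 log units; within the scatter), so on the core of compound 3 isopropyl can stand in place of cyclobutyl on a saturated chain carbon bound to an oxygen on an aromatic ring without a step beyond the scatter. Among these compounds, the only earlier step at this place exchanged one ring for another on the core of compound 1, an at least 4.0-fold higher number from compound 1 to compound 2 (0.60 log units; beyond the scatter), and so it gave no reading for a group without a ring, nor any reading on the core of compound 3. The new step is therefore the first one at this place that ends in a number at both compounds, while compound 2 carries a limit and not a number: the limit of > 100000 nM in this assay, at which 1 of the 4 values shown sits.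

Open, going by these compounds, is whether a longer chain, an amine or a carboxylic acid in place of isopropyl would keep the number in this assay within the scatter of compound 3. Also open, on these data alone, is whether cyclopentyl on the core of compound 3, or isopropyl on the core of compound 1, would follow the same course as the two steps read here.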